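Removing the Hydroxyethyl Arm: Phenyl Straight on the Amine

The compounds below may be only part of what the source reports. "The series", "measured", "known", "first", "only" and "open" are said of these compounds alone.

Measured compounds:
Compound 1, `OCCNCc1nc2c(OCC3CCCCC3)cccc2[nH]1`, in an assay on cells for inhibition of interleukin-5 receptor subunit alpha (Mus musculus), read by WST assay, with a stated time of 48 h, in the presence of a further agent that is not named here (a lower number here means a stronger inhibitor, a higher number a weaker inhibitor), gives 20000 nM.
Compound 2, `OCC(NCc1nc2c(OCC3CCCCC3)cccc2[nH]1)c1ccccc1`, in this assay gives 20000 nM.

Compound 2 stands level with compound 1: the step of no change at the digits printed from compound 1 to compound 2 (within the scatter) lies within the scatter. The next compound, compound 3, `c1ccc(NCc2nc3c(OCC4CCCCC4)cccc3[nH]2)cc1`, differs from compound 2 by phenyl in place of 2-hydroxy-1-phenylethyl on an amine nitrogen, so the amine now carries the phenyl directly and the hydroxyl-bearing chain is gone. Within the data shown here, only one measured step bears on this, and it shows that adding a phenyl at the chain carbon next to the amine, no change at the digits printed from compound 1 to compound 2 (within the scatter), moved nothing. Among the measured compounds shown here, with the hydroxyl removed as well there is no measured step to lean on, so the expectation for compound 3 is a change of no more than the scatter in this assay, no change at the digits printed from compound 2 to compound 3 (within the scatter). Compound 3 is therefore estimated at 20000 nM, within a range from 7000 nM to 50000 nM.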

Compound 3, half-maximal inhibitory concentration: > 30000 nM
Compound 3 was reported as a limit; the forecaster's own chance of this, stated with the estimate: 40%; middle value at least 1.5-fold (0.17 log units) from the limit.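

Compound 3 is reported only as a limit of the assay, > 30000 nM. Replacing 2-hydroxy-1-phenylethyl with phenyl on the amine nitrogen gives an at least 1.5-fold higher number from compound 2 to compound 3 (0.17 log units; that floor lies within the scatter), and replacing 2-hydroxyethyl with phenyl there gives an at least 1.5-fold higher number from compound 1 to compound 3 (0.17 log units; that floor lies within the scatter). Among these compounds, neither step separates compound 3 from the earlier compounds, but where the pair of compound 1 and compound 2 tested only an added phenyl on the chain, these steps add that a phenyl set directly on the amine nitrogen, with the hydroxyl-bearing chain gone, brings no stronger inhibition in this assay.

On these data alone, the change from compound 2 to compound 3 removes the hydroxyl and the chain carbons in one step, so their separate contributions stay open. Also open, as far as these compounds go, is whether a different group on this amine nitrogen, such as benzyl or a longer chain ending in a carboxylic acid, would lower the number.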